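The source may hold more compounds than are shown below. What is called first, only, known or untested is meant among the compounds shown, and "the series" means these compounds.

Compound 1 `Cc1ccc(-n2cc(COc3cccc4cnc(Nc5cccc(Cl)c5)nc34)nn2)c([N+](=O)[O-])c1` gives 4000 nM in a functional assay on MCF7 cells (Homo sapiens) for cytotoxicity, read by cell counting, with a stated time of 48 h; a lower number here means a stronger inhibitor, a higher number a weaker inhibitor. For the measured compounds named here, compound 2 `COc1cccc(-n2cc(COc3cccc4cnc(Nc5cccc(Cl)c5)nc34)nn2)c1` gives 8000 nM in this assay, the higher of the two numbers measured so far; the sole measured step, a 2.0-fold higher number from compound 1 to compound 2 (0.30 log units; within the scatter), stays within the scatter. Compound 3 `COc1ccccc1-n1cc(COc2cccc3cnc(Nc4cccc(Cl)c4)nc23)nn1` differs from compound 2 by 2-methoxyphenyl in place of 3-methoxyphenyl on an aromatic nitrogen. Going by the values given here, no measured step compares 2-methoxyphenyl with 3-methoxyphenyl at this aromatic nitrogen; the only step that bears on the site, a 2.0-fold higher number from compound 1 to compound 2 (0.30 log units; within the scatter), exchanges a different group there and lies within the scatter, so no movement beyond the scatter is expected in this assay. Compound 3 is therefore estimated at 8000 nM, between 3000 nM and 20000 nM. The expected step is no change at the digits printed from compound 2 to compound 3 (within the scatter).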

Compound 3, half-maximal inhibitory concentration: 6000 nM
Compound 3: middle estimate off by 1.3-fold (0.12 log units), on the high side; the range from low to high includes it.
By their numbers in this assay, from the lowest: compounds 1, 3 and 2 (each within the scatter of the next).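

In this assay, 2-methoxyphenyl in place of 3-methoxyphenyl on the aromatic nitrogen gives a 1.3-fold lower number from compound 2 to compound 3 (0.12 log units; within the scatter), the first direct comparison of these two methoxyphenyl groups at this site. 2-Methoxyphenyl in place of 4-methyl-2-nitrophenyl gives a 1.5-fold higher number from compound 1 to compound 3 (0.18 log units; within the scatter), so all three groups shown at this nitrogen lie within the scatter of one another. No supporting data bear on these results.

Still open, as far as these compounds go, is whether a phenyl carrying an amine or a carboxylic acid would move the number beyond the scatter. The same holds for a benzyl group or a longer alkyl chain on this nitrogen.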